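The source may hold more compounds than are shown below. What is called first, only, known or untested is meant among the compounds shown, and "the series" means these compounds.

Values measured so far in an in vivo ADME assay on the whole organism (strain Sprague-Dawley) for pharmacokinetics, with Rattus norvegicus as the target (a lower number here means slower removal, a higher number faster removal of the compound), are these:

Compound 1 `CC(C)[C@@H]1NC[C@@H](C)Oc2ccccc2CCCNC(=O)[C@@H](Cc2ccc(F)cc2)NC(=O)[C@@H](C)N(C)C1=O` - 40 mL/min/kg
Compound 2 `C[C@@H]1C(=O)N[C@H](Cc2ccc(F)cc2)C(=O)NCCCc2ccc(F)cc2OCCN[C@@H](C2CC2)C(=O)N1C` - 28 mL/min/kg

In this assay compound 1 at 40 mL/min/kg and compound 2 at 28 mL/min/kg lie within the usual scatter of each other, so these two numbers do not separate them. Compound 3 `CCC[C@@H]1NC[C@@H](C)Oc2ccccc2CCCNC(=O)[C@@H](Cc2ccc(F)cc2)NC(=O)[C@@H](C)N(C)C1=O` keeps the core of compound 1 and carries propyl in place of isopropyl on a saturated ring carbon, next to the ring nitrogen, with the same atoms joined differently (propyl in place of isopropyl on a saturated ring carbon). No measured pair among these compounds shows this change on its own, so the data give no direct size for the step. The expectation therefore starts from compound 1 at 40 mL/min/kg and allows for no shift beyond the scatter in either direction. The estimated step (a 1.1-fold higher number from compound 1 to compound 3 (0.02 log units; within the scatter)) is expected to stay within that scatter. Compound 3 is expected at 42 mL/min/kg (estimated range 22 mL/min/kg to 75 mL/min/kg).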

Compound 3, clearance: 41 mL/min/kg
Compound 3: middle estimate off by 1.0-fold (0.01 log units), on the high side; the measured number falls inside the stated range.
By their numbers in this assay, from the lowest: compounds 2, 1 and 3 (each within the scatter of the next).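

In this assay, within the data shown here, the step at this saturated ring carbon, next to the ring nitrogen, gives the first direct reading for this position: propyl in place of isopropyl produces a 1.0-fold higher number from compound 1 to compound 3 (0.01 log units; within the scatter). The two groups have the same count of 3 carbon atoms and neither has a ring, so this change only rejoins the same atoms, and that rejoining does not separate the two compounds in this read-out. The measurements offer no independent information that would explain this outcome.

The compounds shown leave open whether a longer chain such as butyl, or a chain ending in an amine or a carboxylic acid, on this ring carbon would give a step beyond the scatter in this assay. Compound 2 differs from compound 1 in more than one place, so its number cannot be read as a step at this position, and the contribution of each of its differences remains unresolved.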